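The source may hold more compounds than are shown below. What is called first, only, known or untested is meant among the compounds shown, and "the series" means these compounds.

Compound 1 `N#Cc1ccc(/C=N/NC(=O)Nc2ccc(Oc3ccnc4[nH]ccc34)c(F)c2)cc1`: 850 nM
Compound 2 `O=C(N/N=C/c1ccc([N+](=O)[O-])cc1)Nc1ccc(Oc2ccnc3[nH]ccc23)c(F)c1`: 3030 nM
Compound 3 `O=C(N/N=C/c1ccc(O)cc1)Nc1ccc(Oc2ccnc3[nH]ccc23)c(F)c1`: 1950 nM

All three values come from a functional assay on HepG2 cells (Homo sapiens) for antiproliferative activity, read by MTT assay, with a stated time of 72 h; a lower number here means a stronger inhibitor, a higher number a weaker inhibitor. The compounds differ from one another in a single group on an aromatic carbon. Compound 3 has a value of 1950 nM. Its nearest neighbour is compound 2, shown by a 1.6-fold lower number from compound 2 to compound 3 (0.19 log units; within the scatter). The gap to the lowest number is larger, with a 2.3-fold higher number from compound 1 to compound 3 (0.36 log units; beyond the scatter).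

Compound 4 `COc1ccc(/C=N/NC(=O)Nc2ccc(Oc3ccnc4[nH]ccc34)c(F)c2)cc1` makes one change to compound 3: methyl in place of hydrogen on an oxygen on an aromatic ring. This is methyl in place of hydrogen on an oxygen on an aromatic ring, so hydroxy becomes methoxy. Going by the values given here, no measured step makes this exact change, so the evidence is only indirect. The nearest guide is the set of group swaps among the measured compounds, and the largest of these is a 3.6-fold higher number from compound 1 to compound 2 (0.55 log units; beyond the scatter). Even that step is modest, and the steps do not indicate which way a methyl would push the number. In this assay, a small step in either direction is therefore expected, quite possibly none beyond the scatter. The expected change is a 1.1-fold lower number from compound 3 to compound 4 (0.03 log units; within the scatter). For compound 4 the estimated value is 1800 nM, with an expected range from 700 nM to 4500 nM.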

Compound 4, half-maximal inhibitory concentration: 1770 nM
Estimate against measurement, compound 4: 1.0-fold (0.01 log units) above; low and high end bracket the measured number.
By their numbers in this assay, from the lowest: compound 1; then compounds 4, 3 and 2 (each within the scatter of the next).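

In this assay, going by these compounds alone, the move from hydroxy to methoxy gives the first direct look at this oxygen, and losing its hydrogen to a methyl leaves the number within the scatter (a 1.1-fold lower number from compound 3 to compound 4 (0.04 log units; within the scatter)). So, in these compounds, the hydrogen on this oxygen is not needed for the level of antiproliferative activity seen in these cells, and the added methyl carries no measurable penalty or gain. Methoxy also cannot be told apart from nitro (a 1.7-fold lower number from compound 2 to compound 4 (0.23 log units; within the scatter)), but it does differ from the nitrile (a 2.1-fold higher number from compound 1 to compound 4 (0.32 log units; beyond the scatter)), so compound 1 remains the most potent of the four, and the hydroxy, methoxy and nitro compounds form a single group within the scatter.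

The information at hand gives no reason why the nitrile stands apart from the other three groups, and a single cell-based read-out cannot separate the possible explanations. Going by these compounds, it also remains open whether a longer chain on this oxygen, such as ethoxy, or an amine or a carboxylic acid in place of the group on the aromatic carbon, would move the number beyond the scatter.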